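This account rests on a few compounds, and the source may have more. Where it says the series, first, only, none or still open, it means among the compounds named here.

Working notes on the series, all compounds sharing one core. In a physicochemical assay for lipophilicity (a higher number here means a more lipophilic compound, a lower number a more polar compound), compound 1 `CC(C)(C)C#Cc1cc(N(C(=O)[C@H]2CC[C@H](C)CC2)[C@H]2CC[C@@H](Oc3ccc(=O)[nH]n3)CC2)c(C(=O)O)s1` gives 1.8 and compound 2 `CC(C)(C)C#Cc1cc(N(C(=O)[C@H]2CC[C@H](C)CC2)[C@H]2CC[C@H](OC3COC3)CC2)c(C(=O)O)s1` gives 2.6. Compound 2 therefore stands higher of the two numbers available, and the gap to compound 1 lies beyond the scatter. Compound 3 `CC(C)(C)C#Cc1cc(N(C(=O)[C@H]2CC[C@H](C)CC2)[C@H]2CC[C@@](O)(CO[C@H]3CCOC3)CC2)c(C(=O)O)s1` offers no comparison, as its entry reads "not determined" (no result reported).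

The next compound to read is compound 4 `CC(C)(C)C#Cc1cc(N(C(=O)[C@H]2CC[C@H](C)CC2)[C@H]2CC[C@H](Oc3ccccn3)CC2)c(C(=O)O)s1`. Relative to compound 2, the change is pyridin-2-yl in place of oxetan-3-yl on an oxygen on a saturated carbon. In words, pyridin-2-yl stands in place of oxetan-3-yl on an oxygen on a saturated carbon, and the rest of the structure is unchanged.

Among the compounds with values here, no measured pair differs in one place only, so this change has no direct precedent here. Compound 1 carries a different group on that oxygen and, at 1.8, shows that the group can matter, but it gives no size for this particular swap. The estimate therefore starts from compound 2 at 2.6 and rests on the structural change alone.

The expected change is upward and beyond the scatter, with an estimated a number 0.70 log units higher from compound 2 to compound 4 (beyond the scatter). Compound 4 is estimated at 3.3, with an expected range of 2.8 to 3.8.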

Compound 4, distribution coefficient: 3
For compound 4 the middle estimate is 0.30 log units above the measured one; low and high end bracket the measured number.
By their numbers in this assay, from the lowest: compound 1; then compound 2; then compound 4.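

In this assay, within the data shown here, pyridin-2-yl in place of oxetan-3-yl on an oxygen on a saturated carbon gives a number 0.40 log units higher from compound 2 to compound 4 (beyond the scatter), and this is the only pair so far that differs in one place. Among these compounds, the pair shows that a change confined to this oxygen is enough to move the number beyond the scatter with the rest of the structure unchanged, which the earlier compounds could not show on their own. The two groups have the same counts of hydrogen-bond donors and acceptors and no net charge, yet they differ in heavy atoms, ring size and aromatic character, and this single step cannot separate those differences. No measurement at hand accounts for the size or direction of the step.

With one step at one place, the series gives no trend across groups on this oxygen. On these data alone, it remains open where a phenyl ring, a morpholine ring, a primary amine or a longer alkyl chain on that oxygen would fall relative to these two groups, and whether the step would keep its direction and size on a different core.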